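The source may report more compounds than this note shows. Statements on the series, on what has been measured and on what is new or still open speak of the compounds shown alone.

Three compounds share one core and differ only in the aromatic group fixed to the ring nitrogen of the saturated six-membered ring at the far end of the molecule. Compound 1 `CCCc1nc(-c2ccccc2)c(CNCCN2CCN(c3ccc(C)cc3)CC2)o1` carries 4-methylphenyl there, compound 2 `CCCc1nc(-c2ccccc2)c(CNCCN2CCN(c3ccc(Cl)cc3)CC2)o1` carries 4-chlorophenyl, and compound 3 `CCCc1nc(-c2ccccc2)c(CNCCN2CCN(c3ccccn3)CC2)o1` carries pyridin-2-yl. In an assay on HEK293 cells for inhibition of Voltage-dependent T-type calcium channel subunit alpha-1G (Homo sapiens), read by fluorescence, tested at 10 uM (on this read-out lower numbers stand for less inhibition and higher numbers for more inhibition at the one concentration tested (going by the name of the read-out)), compound 1 gives 48.1%, compound 2 gives 55.8%, and compound 3 gives 48.1%. Compound 3 thus stands level with compound 1 at the digits shown, the step of no change at the digits printed from compound 1 to compound 3 (within the scatter) being flat, while toward compound 2 the step of a number 7.7 percentage points lower from compound 2 to compound 3 (within the scatter) also stays within the scatter of repeated measurements.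

Compound 4 `CCCc1nc(-c2ccccc2)c(CNCCN2CCN(c3ccccc3F)CC2)o1` has not yet been measured. It differs from compound 3 by 2-fluorophenyl in place of pyridin-2-yl on an amine nitrogen in a ring. The measured steps that bear on this change are the two in which the group on the same ring nitrogen was exchanged, no change at the digits printed from compound 1 to compound 3 (within the scatter) and a number 7.7 percentage points lower from compound 2 to compound 3 (within the scatter); neither moved beyond the scatter. Since three different aromatic groups on this nitrogen gave numbers within the scatter of one another, a fourth is expected to do the same, so the expected step is a number 1.9 percentage points higher from compound 3 to compound 4 (within the scatter). Compound 4 is therefore estimated at 50% in this assay, with an expected range from 36% to 64%.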

Compound 4, a percentage reported as inhibition, at one concentration (the size of the read-out at that concentration, not a potency): 46.5%
Compound 4: the middle estimate sits 3.5 percentage points above what was measured; measured number inside the range.
By their numbers in this assay, from the lowest: compounds 4, 1, 3 and 2 (each within the scatter of the next).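

In this assay, replacing pyridin-2-yl with 2-fluorophenyl removes the ring nitrogen and its counted hydrogen-bond acceptor and adds a fluorine, yet the result is a number 1.6 percentage points lower from compound 3 to compound 4 (within the scatter) and not a step beyond the scatter. The comparisons with the two substituted phenyl groups agree, giving a number 1.6 percentage points lower from compound 1 to compound 4 (within the scatter) and a number 9.3 percentage points lower from compound 2 to compound 4 (within the scatter), so 2-fluorophenyl now joins 4-methylphenyl, 4-chlorophenyl and pyridin-2-yl as a group that cannot be told apart from the others on this amine nitrogen in a ring. No measurement here accounts for how closely these four numbers sit together.

On these data alone, all four groups are single six-membered aromatic rings, so it remains open whether a saturated ring such as cyclohexyl, a small chain such as methyl, a larger aromatic system such as naphthyl, or a plain hydrogen on this nitrogen would stay within the same scatter. The shared core is also constant throughout, so these compounds cannot show what a shorter chain in place of the propyl group or a pyridine ring in place of its phenyl would do.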